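Chloro for methyl on the aryl ring of compound 2

The source may report more compounds than this note shows. Statements on the series, on what has been measured and on what is new or still open speak of the compounds shown alone.

Two members of the series have numbers in a functional assay on A549 cells (Homo sapiens) for cytotoxicity, read by MTT assay, with a stated time of 48 h (on this read-out lower numbers stand for stronger inhibition and higher numbers for weaker inhibition), so far. Compound 1 `CCOC(=O)c1c(-c2cc3ccc(OC)cc3oc2=O)nn(-c2cccc(Cl)c2)c1C(=O)OCC` gives 221000 nM in this assay, and compound 2 `CCOC(=O)c1c(-c2cc3ccc(OCC=C(C)C)cc3oc2=O)nn(-c2cccc(C)c2)c1C(=O)OCC` gives 178000 nM in this assay; the two numbers sit within the scatter of one another, so neither stands apart. Compound 3 `CCOC(=O)c1c(-c2cc3ccc(OCC=C(C)C)cc3oc2=O)nn(-c2cccc(Cl)c2)c1C(=O)OCC` remains to be measured. It differs from compound 2 by chloro in place of methyl on an aromatic carbon. Among the compounds with values here, no measured pair shows this change alone, and compound 1 carries it together with a second difference, so the step from compound 2 is expected to be a 1.1-fold higher number from compound 2 to compound 3 (0.03 log units; within the scatter), none beyond the scatter. Compound 3 is estimated at 190000 nM in this assay, within 90000 nM to 400000 nM.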

Compound 3, half-maximal inhibitory concentration: 163000 nM
Compound 3: the middle estimate sits 1.2-fold (0.07 log units) above what was measured; the measured number falls inside the stated range.
By their numbers in this assay, from the lowest: compounds 3, 2 and 1 (each within the scatter of the next).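

Within the data shown here, this pair gives the first clean reading of 3-methylphenyl to 3-chlorophenyl: in this assay the swap gives (a 1.1-fold lower number from compound 2 to compound 3 (0.04 log units; within the scatter)), so with the rest of the structure held constant, chloro and methyl at this ring position cannot be told apart. The added 2-methylprop-1-en-1-yl on the saturated chain carbon bound to the oxygen also stays inside the scatter (a 1.4-fold lower number from compound 1 to compound 3 (0.13 log units; within the scatter)). No supporting data bear on the reason for either result.

As far as these compounds go, whether an amine or a carboxylic acid at this ring position would separate from these values remains open. So does the effect of a longer chain on the oxygen.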